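A few compounds are considered here, and "the series" means these few. Any claim that something is new, unique, unknown or untested is made for them only; others in the source may bear on it.

Measured compounds:
- compound 1 `CC1(C)S[C@@H]2/C(=C\C(=O)c3ccco3)C(=O)N2[C@H]1C(=O)OC(c1ccccc1)c1ccccc1` gives 61500 nM in a functional assay on NCI-H1299 cells (Homo sapiens) for cytotoxicity, read by MTT assay, with a stated time of 48 h; a higher number here means a weaker inhibitor, a lower number a stronger inhibitor.
- compound 2 `CC(=O)/C=C1\C[C@H]2SC(C)(C)[C@H](C(=O)OC(c3ccccc3)c3ccccc3)N2C1=O` reaches only a limit in this assay, > 100000 nM.

For the measured compounds named here, compound 1 carries the only number given in this assay; the other value shown is a limit, and the limit of > 100000 nM in this assay, at which 1 of the 2 values shown sits, marks where that limit sits. Going by the values given here, no step between measured compounds can be sized here, so the change to compound 3 rests on the structural difference alone.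

Compound 3 `CCOC(=O)/C=C1/C(=O)N2[C@@H]1SC(C)(C)[C@@H]2C(=O)OC(c1ccccc1)c1ccccc1` differs from compound 1 by ethoxy in place of furan-2-yl on a carbonyl carbon. Among the compounds with values here, with no measured step to lean on, the expectation is a step of a 1.3-fold higher number from compound 1 to compound 3 (0.11 log units; within the scatter) that stays close to the scatter, with the wider side of the range left open towards weaker inhibition, since a limit already appears in this assay.

Compound 3 is expected at 80000 nM in this assay, within a range of 30000 nM to 200000 nM.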

Compound 3, half-maximal inhibitory concentration: 15000 nM
Compound 3: middle estimate off by 5.3-fold (0.73 log units), on the high side, and the stated range ends above it.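

The carbonyl carbon on the double-bonded chain carbon is a place where the group counts in this assay: ethoxy in place of furan-2-yl gives a 4.1-fold lower number from compound 1 to compound 3 (0.61 log units; beyond the scatter). The furan-2-yl ring is therefore not required for the cytotoxicity seen in this series, since compound 3 carries no ring at this place and still has the lower number. No measured property among the data given accounts for this step.

The change from (furan-2-yl)carbonyl to ethoxycarbonyl removes the ring and replaces the ketone with an ester in one step, so the contribution of each stays unresolved. Going by these compounds, it also remains open whether a longer chain such as butoxy, or an amine on the same carbonyl carbon, would extend the step or reverse it.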